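The source may hold more compounds than are shown below. What is called first, only, known or untested is meant among the compounds shown, and "the series" means these compounds.

Measured in a functional assay on MDA-MB-436 cells (Homo sapiens) for antiproliferative activity, read by MTT assay, with a stated time of 48 h; a higher number here means a weaker inhibitor, a lower number a stronger inhibitor:
- compound 1 `C=CS(=O)(=O)N1CCN(c2nc(OC[C@H]3CCCN3C)nc3sc(-c4ccc(C#N)cc4)cc23)CC1`: 2290 nM
- compound 2 `C=CS(=O)(=O)N1CCN(c2nc(OC[C@H]3CCCN3C)nc3sc(-c4ccc(OC)nc4)cc23)CC1`: 4980 nM

Not yet measured:
- compound 3 `C=CS(=O)(=O)N1CCN(c2nc(OC[C@H]3CCCN3C)nc3sccc23)CC1`

Of the two measured compounds, compound 2 stands highest at 4980 nM, with compound 1 as its nearest neighbour. Compound 3 differs from compound 2 as follows: hydrogen in place of 6-methoxypyridin-3-yl on an aromatic carbon. In short, hydrogen in place of 6-methoxypyridin-3-yl on an aromatic carbon.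

For the measured compounds named here, only one measured step bears on this, a 2.2-fold higher number from compound 1 to compound 2 (0.34 log units; beyond the scatter), which is modest and beyond the scatter. That step exchanges one group for another at this place, whereas compound 3 has no such group, so it is only a loose guide. Going by the values given here, no measured compound carries hydrogen here. A larger step than that one is expected in this assay, towards a higher number. The expected change is a 2.4-fold higher number from compound 2 to compound 3 (0.38 log units; beyond the scatter). Compound 3 is estimated at 12000 nM, with an expected range of 5000 nM to 40000 nM.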

Compound 3, half-maximal inhibitory concentration: > 50000 nM
Compound 3 was reported as a limit (the forecaster's own chance of this, stated with the estimate: 25%); middle value at least 4.1-fold (0.61 log units) away from the limit.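

In this assay, compound 3 stands as a limit and not a number: the limit of > 50000 nM in this assay, at which 1 of the 3 values shown sits. Hydrogen in place of 6-methoxypyridin-3-yl on this aromatic carbon next to the ring sulfur gives an at least 10-fold higher number from compound 2 to compound 3 (1.00 log units; beyond the scatter), and hydrogen in place of 4-cyanophenyl gives an at least 21-fold higher number from compound 1 to compound 3 (1.33 log units; beyond the scatter). Exchanging one aromatic ring for the other gave only a 2.2-fold higher number from compound 1 to compound 2 (0.34 log units; beyond the scatter), so across these compounds, having a six-membered aromatic ring on this carbon counts for more than which of the two it is.

On these data alone, the true size of both steps to compound 3 stays open. Also open, as far as these compounds go, is whether a methyl group or a saturated ring such as piperidine on this carbon would stay near compound 1 and compound 2 or fall with compound 3.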